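A few compounds are considered here, and "the series" means these few. Any claim that something is new, unique, unknown or untested is made for them only; others in the source may bear on it.

In a functional assay on HT-29 cells (Homo sapiens) for cytotoxicity, read by MTT assay, with a stated time of 6 days (on this read-out higher numbers stand for an effect only at larger amounts of compound and lower numbers for an effect already at smaller amounts), compound 1 (`COC(=O)c1c(-c2cc(OC)cc(OC)c2)oc2ccccc2c1=O`) gives 6.99 ug/mL. Compound 2 (`COC(=O)c1c(-c2ccc(OC)cc2)oc2ccccc2c1=O`) gives > 25 ug/mL, which is a limit of the assay and not a number. Compound 3 (`COC(=O)c1c(-c2ccc(Br)cc2)oc2ccccc2c1=O`) differs from compound 2 in one place, with bromo in place of methoxy on an aromatic carbon, para to a large group: bromo in place of methoxy on an aromatic carbon. Among the measured compounds shown here, no measured pair isolates this change, so any expectation for this assay rests on little. A modest step toward lower numbers is expected, and it may not exceed the usual scatter. Compound 1 at 6.99 ug/mL shows that a measurable value is possible in this series. The estimated step of an at least 1.3-fold lower number from compound 2 to compound 3 (0.14 log units; that floor lies within the scatter) is therefore small. For compound 3 the expected value is 18 ug/mL, with an estimated range of 7 ug/mL to 40 ug/mL.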

Compound 3, concentration for half-maximal effect: > 25 ug/mL
Compound 3 gave a limit, no number; the forecaster's own chance of this, stated with the estimate: 50%; middle value at least 1.3-fold (0.14 log units) away from the limit.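

In this assay, among the compounds shown here, compound 2 and compound 3 each stop at a limit and give no number, so no step between them can be read: the limit of > 25 ug/mL in this assay, at which 2 of the 3 values shown sit. Going by these compounds, whether bromo and methoxy at this place differ in effect remains open.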